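A Hydroxy Group Added to the Pendant Phenyl

The source may report more compounds than this note shows. Statements on the series, on what has been measured and on what is new or still open speak of the compounds shown alone.

Three compounds share one core. Compound 1 `Cc1ccc(-c2c3ccc4ccccc4c3nc3c2c(C)nc2c4ccccc4ccc32)cc1` gives 68.7 ug/mL in a functional assay, read by spectrophotometry, with a stated time of 15 min; on this read-out higher numbers stand for weaker inhibition and lower numbers for stronger inhibition. Compound 2 `Cc1nc2c3ccccc3ccc2c2nc3c(ccc4ccccc43)c(C)c12` gives 89.6 ug/mL in this assay, and compound 3 `Cc1nc2c3ccccc3ccc2c2nc3c(ccc4ccccc43)c(-c3ccccc3)c12` gives 84.6 ug/mL in this assay. Compound 3 stands second highest of the three numbers, with compound 2 nearest and compound 1 furthest, and every gap is within the scatter. The measured steps agree: a 1.3-fold higher number from compound 1 to compound 2 (0.12 log units; within the scatter) and a 1.2-fold higher number from compound 1 to compound 3 (0.09 log units; within the scatter), while a 1.1-fold lower number from compound 2 to compound 3 (0.02 log units; within the scatter). Compound 4 `Cc1nc2c3ccccc3ccc2c2nc3c(ccc4ccccc43)c(-c3ccc(O)cc3)c12` differs from compound 3 in one place: hydroxy in place of hydrogen on an aromatic carbon. Among the measured compounds shown here, no measured step introduces a hydroxy group, so this change has no direct precedent in the set; what the set does show is that exchanging the group on an aromatic carbon of the core, methyl, phenyl or 4-methylphenyl, has never moved this assay beyond the scatter. Compound 4 is therefore expected to give about 80 ug/mL in this assay, within 40 ug/mL to 160 ug/mL. The estimated step of a 1.1-fold lower number from compound 3 to compound 4 (0.02 log units; within the scatter) is expected to stay within the scatter.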

Compound 4, half-maximal inhibitory concentration: 44.1 ug/mL
Compound 4: middle estimate off by 1.8-fold (0.26 log units), on the high side, and the stated range covers the measured number.
By their numbers in this assay, from the lowest: compounds 4, 1, 3 and 2 (each within the scatter of the next, the first and the last beyond it).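

In this assay, hydroxy in place of hydrogen on the pendant phenyl gives a 1.9-fold lower number from compound 3 to compound 4 (0.28 log units; within the scatter) and hydroxy in place of methyl on that ring gives a 1.6-fold lower number from compound 1 to compound 4 (0.19 log units; within the scatter), so neither of these two steps leaves the scatter. Among the compounds shown here, only 4-hydroxyphenyl in place of methyl on an aromatic carbon of the core gives a step beyond it, a 2.0-fold lower number from compound 2 to compound 4 (0.31 log units; beyond the scatter), and this modest step is the first in the set to clear the scatter. The group at this carbon can therefore move the read-out, but the data shown give no explanation for this.

From the compounds shown here alone, it remains open whether a methoxy group, an amine or a carboxylic acid at the same place on the phenyl would give a similar number. Going by these compounds, it is also open whether hydroxy placed elsewhere on that ring would do so.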